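The source may hold more compounds than are shown below. What is called first, only, known or untested is meant among the compounds shown, and "the series" means these compounds.

Compound 1 `COc1cc(/C=C2\CN(C)C/C(=C\c3ccc(C#N)cc3)C2=O)cc(OC)c1`: 940 nM
Compound 2 `COc1cc(/C=C2\CN(C)C/C(=C\c3ccc(Cl)c(Cl)c3)C2=O)cc(OC)c1OC`: 5330 nM

Both compounds were tested in a functional assay on THP-1 cells (Homo sapiens) for cytotoxicity, read by MTT assay, with a stated time of 24 h; a lower number here means a stronger inhibitor, a higher number a weaker inhibitor. Of the two, compound 2 has the higher number at 5330 nM, which makes it the weaker inhibitor, and its gap to compound 1 lies beyond the usual scatter.

The next compound, compound 3 `COc1cc(/C=C2\CN(C)C/C(=C\c3ccc(C#N)cc3)C2=O)cc(OC)c1OC`, has not yet been measured. It differs from compound 2 in one place: 4-cyanophenyl in place of 3,4-dichlorophenyl on a double-bonded chain carbon bound to a double-bonded ring carbon. Here 4-cyanophenyl replaces 3,4-dichlorophenyl on a double-bonded chain carbon bound to a double-bonded ring carbon.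

A lower number is expected in this assay because compound 1 also carries 4-cyanophenyl and gives 940 nM. The expected change is a 3.3-fold lower number from compound 2 to compound 3 (0.52 log units; beyond the scatter), a moderate step toward stronger inhibition. Two measured compounds are thin support, so the range is kept wide. For compound 3 the estimated value is 1600 nM, with an expected range from 600 nM to 4500 nM.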

Compound 3, half-maximal inhibitory concentration: 820 nM
Estimate against measurement, compound 3: 2.0-fold (0.29 log units) above; the measured number falls inside the stated range.
By their numbers in this assay, from the lowest: compounds 3 and 1 (each within the scatter of the next); then compound 2.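

In this assay, among these compounds, putting 4-cyanophenyl in place of 3,4-dichlorophenyl on a double-bonded chain carbon bound to a double-bonded ring carbon gives a 6.5-fold lower number from compound 2 to compound 3 (0.81 log units; beyond the scatter), the first reading of this change with the rest of the molecule held constant. Methoxy in place of hydrogen on an aromatic carbon gives a 1.1-fold lower number from compound 1 to compound 3 (0.06 log units; within the scatter), so with 4-cyanophenyl in place, this methoxy group leaves the two compounds indistinguishable in this measurement. No measurement shown here explains either result.

The step does not separate gaining the nitrile from losing the two chlorine atoms; a plain phenyl or a 4-chlorophenyl group at this place could help tell these apart. As far as these compounds go, it also remains open whether the methoxy group would make as little difference alongside 3,4-dichlorophenyl.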